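This account rests on a few compounds, and the source may have more. Where it says the series, first, only, none or still open, it means among the compounds named here.

Measured compounds:
compound 1 `O=S(=O)(Nc1ccccc1)c1ccccc1` gives 9.1 in an ADME assay.
compound 2 `O=S(=O)(Nc1ccccc1)c1ccc(Cl)cc1` gives 8.47 in this assay.
compound 3 `O=[N+]([O-])c1cccc(NS(=O)(=O)c2ccc(Cl)cc2)c1` gives 7.51 in this assay.

Compound 2 stands second highest of these three: a number 0.63 log units lower from compound 1 to compound 2 (beyond the scatter) came with chloro in place of hydrogen on an aromatic carbon, and a number 0.96 log units lower from compound 2 to compound 3 (beyond the scatter) came with nitro in place of hydrogen on an aromatic carbon. Compound 4 `Cc1ccc(NS(=O)(=O)c2ccc(Cl)cc2)cc1` is not yet measured; it differs from compound 2 by methyl in place of hydrogen on an aromatic carbon. Neither measured step involves a methyl, so neither is a direct guide; both only show that one added group on an aromatic carbon can move this assay by a modest amount. For compound 4 a small step is expected, a number 0.18 log units higher from compound 2 to compound 4 (within the scatter), slightly upward or none beyond the scatter. Compound 4 is therefore estimated at 8.65, within 8.35 to 9.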

Compound 4, acid dissociation constant: 8.78
Compound 4: the middle estimate sits 0.13 log units below what was measured; measured number inside the range.
By their numbers in this assay, from the lowest: compound 3; then compound 2; then compound 4; then compound 1.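

In this assay, methyl in place of hydrogen, para to a large group, gives a number 0.31 log units higher from compound 2 to compound 4 (beyond the scatter). Going by these compounds alone, this is the first upward step, as the chloro and nitro changes both lowered the number, so one added group on an aromatic carbon can move this read-out in either direction. Nothing available here explains the direction of the methyl step.

As far as these compounds go, whether an amine or a longer chain at this same place would also raise the number remains open. So does whether methyl would give a similar step on the core of compound 1.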